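Removing a Methyl from an Aromatic Oxygen on Two Cores

The source may report more compounds than this note shows. Statements on the series, on what has been measured and on what is new or still open speak of the compounds shown alone.

Measured so far in a physicochemical assay for lipophilicity; on this read-out lower numbers stand for lower lipophilicity and higher numbers for higher lipophilicity:
compound 1 `CN(C)c1ccc(-c2nc3ccc(O)cc3s2)cn1` gives 2.4
compound 2 `COc1ccc2nc(-c3ccc(N(C)C)nc3)sc2c1` gives 4.2
compound 3 `COc1ccc2nc(-c3ccc(N(C)C)nc3)oc2c1` gives 3.7

Compound 2 and compound 1 differ in one place: hydrogen in place of methyl on an oxygen on an aromatic ring. This change produced a number 1.80 log units lower from compound 2 to compound 1 (beyond the scatter) in this assay.

Compound 3 carries a different core from compound 2; the difference between the two cores is not broken down here. In this assay compound 3 sits second highest of the three, below compound 2 and above compound 1, and both gaps lie beyond the scatter.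

Compound 4 `CN(C)c1ccc(-c2nc3ccc(O)cc3o2)cn1` has not yet been measured. It differs from compound 3 by hydrogen in place of methyl on an oxygen on an aromatic ring, the same change that separates compound 2 from compound 1, made here on the core of compound 3.

The expectation for compound 4 rests on a single precedent. Because the earlier step of a number 1.80 log units lower from compound 2 to compound 1 (beyond the scatter) was large and well beyond the scatter, a step of similar size, a number 1.70 log units lower from compound 3 to compound 4 (beyond the scatter), is expected from compound 3 to compound 4 in this assay. Going by these compounds, whether the second core answers the same way is untested, so the expected range is kept wide. Compound 4 is estimated at 2, expected to fall between 1.4 and 2.6.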

Compound 4, distribution coefficient: 1.9
Estimate against measurement, compound 4: 0.10 log units above; the range from low to high includes it.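

In this assay, putting hydroxy in place of methoxy gave a number 1.80 log units lower from compound 3 to compound 4 (beyond the scatter) and on the other core gave a number 1.80 log units lower from compound 2 to compound 1 (beyond the scatter) with the same printed size, so this change carried from one core to the other without any difference in the size of the step. This agreement rests on just one matched pair on each of two cores, so it shows that the step held for these four compounds and does not establish a rule for any further core in the series. Nothing available here accounts for the two steps matching, and no explanation can be offered for the result.

The compounds shown leave open whether the match would persist with an ethyl group, a longer chain or an acetyl group on the oxygen, or with an amine or a carboxylic acid in place of the hydroxy. They also leave open whether a third core would answer the same way.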